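From a Furan to a Fluorophenyl on a Shared Core

This account rests on a few compounds, and the source may have more. Where it says the series, first, only, none or still open, it means among the compounds named here.

Measured compounds:
Compound 1, `Cc1nn(C)c2nc(NNC(=O)Nc3cc(Cl)nc(Cl)c3)cc(-c3ccco3)c12`: 6520 nM
Compound 2, `CCCCOc1cc(NC(=O)NNc2cc(-c3ccc(OC)cc3)c3cnn(C)c3n2)cc(Cl)n1`: 4150 nM

Of the compounds shown here, two have been measured in an assay on isolated protein for binding affinity to sphingosine 1-phosphate receptor 2 (Homo sapiens), read by surface plasmon resonance; a lower number here means tighter binding, a higher number weaker binding. Compound 1 gives 6520 nM and compound 2 gives 4150 nM. The two numbers lie within the usual scatter of each other, so neither compound can be called the tighter binder on this evidence. Going by the values given here, no step between compounds that differ in only one place has been measured, so nothing yet shows how a single exchange of a group moves the number.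

Compound 3, `Cc1nn(C)c2nc(NNC(=O)Nc3cc(Cl)nc(Cl)c3)cc(-c3ccc(F)cc3)c12`, has not yet been measured. It differs from compound 1 in one place: 4-fluorophenyl in place of furan-2-yl on an aromatic carbon. Among the compounds with values here, nothing among the measured compounds tells what this exchange does, so the step is expected to be small, in either direction, or none beyond the scatter; the estimated step is a 1.3-fold lower number from compound 1 to compound 3 (0.12 log units; within the scatter). Compound 3 is expected to give about 5000 nM, within a range from 1500 nM to 16000 nM.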

Compound 3, dissociation constant: 980 nM
Compound 3: middle estimate off by 5.1-fold (0.71 log units), on the high side, outside the stated range (below it).
By their numbers in this assay, from the lowest: compound 3; then compounds 2 and 1 (each within the scatter of the next).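

The earlier compounds shown here could not show what a single exchange does, and this pair shows that the aromatic carbon opposite the ring nitrogen is not a neutral place for change. Exchanging furan-2-yl for 4-fluorophenyl there gives a 6.7-fold lower number from compound 1 to compound 3 (0.82 log units; beyond the scatter) in this assay and, since the rest of the structure stays the same, the step belongs to this one exchange. Nothing at hand says what about the exchange lowers the number.

A plain phenyl group at this position would show whether the fluorine counts or the six-membered ring alone is enough, and a 4-chlorophenyl or pyridine ring would show how far the step extends. Going by these compounds, compound 2 differs from compound 3 in more than one place, so whether the step carries over to other substituents on the dichloropyridine end also remains open.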